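The compounds below may be only part of what the source reports. "The series", "measured", "known", "first", "only" and "open" are said of these compounds alone.

Measured compounds:
compound 1 `CC(C)N(C(=O)CN1C=CN(c2ccccc2)C(=O)C(Cc2n[nH]c3ccccc23)C1=O)c1ccc(OC(F)(F)F)cc1` — compound 1 gives 22.4 nM
compound 2 `CC(C)N(C(=O)CN1C=CN(c2ccccc2)C(=O)[C@@H](Cc2n[nH]c3cc(F)ccc23)C1=O)c1ccccc1` — compound 2 gives 31600 nM; > 30000 nM (2 entries)
compound 3 `CC(C)N(C(=O)CN1C=CN(c2ccccc2)C(=O)C(Cc2n[nH]c3cc(F)ccc23)C1=O)c1ccc(F)cc1` — compound 3 gives 14.1 nM

In a functional assay on CHO cells for agonist activity at Melanocyte-stimulating hormone receptor (Homo sapiens), read by a luciferase reporter, with a stated time of 4 h (a higher number here means that more compound is needed for the effect, a lower number that less compound is needed), compound 1 stands at the higher of the two plain numbers, though its gap to compound 3 lies within the scatter, so no order between them is claimed. For compound 2 the readings in this assay are 31600 nM; > 30000 nM (2 entries). Within the data shown here, no two measured compounds differ in a single place, so no measured step is available.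

Compound 4 `COc1ccc(N(C(=O)CN2C=CN(c3ccccc3)C(=O)C(Cc3n[nH]c4ccccc34)C2=O)C(C)C)cc1` is not yet measured. It differs from compound 1 by methyl in place of trifluoromethyl on an oxygen on an aromatic ring; cut one bond further out, the change reads trifluoromethoxy to methoxy, or 4-(trifluoromethoxy)phenyl to 4-methoxyphenyl. Among the measured compounds shown here, compounds 1 and 3 both carry a group on that ring and both give low numbers in this assay, which is the only guide here. A small step toward a higher number, not clearly beyond the scatter, is expected from compound 1 to compound 4, namely a 1.8-fold higher number from compound 1 to compound 4 (0.25 log units; within the scatter). For compound 4 the estimate in this assay is 40 nM, with a range from 10 nM to 250 nM.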

Compound 4, half-maximal effective concentration: 29.5 nM
The estimate for compound 4 lay 1.4-fold (0.13 log units) above the measured number; the range from low to high includes it.
By their numbers in this assay, from the lowest: compounds 3, 1 and 4 (each within the scatter of the next, the first and the last beyond it).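

In this assay, among these compounds, the first single-place comparison gives a 1.3-fold higher number from compound 1 to compound 4 (0.12 log units; within the scatter) for methyl in place of trifluoromethyl on an oxygen on an aromatic ring. With compound 4 at 29.5 nM, 4-methoxyphenyl and 4-(trifluoromethoxy)phenyl cannot be told apart here, so the fluorine atoms of this group are not required for a low number in this assay. No measurement at hand speaks to why this step has the size it has.

Open, going by these compounds, is whether a longer chain on the same oxygen, such as ethyl or butyl, stays in this range. Equally open, on these data alone, is whether a group not joined through oxygen, such as an amine or a carboxylic acid, would do so with the rest of compound 1 unchanged.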